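Amide in place of ketone on the coumarin side chain

The source may report more compounds than this note shows. Statements on the series, on what has been measured and on what is new or still open speak of the compounds shown alone.

Of the compounds shown here, three sharing one core have been measured in an assay on isolated protein (strain Sprague-Dawley) for inhibition of Amine oxidase [flavin-containing] B (Rattus norvegicus), read by spectrophotometry, with a stated time of 5 min; on this read-out lower numbers stand for stronger inhibition and higher numbers for weaker inhibition. Compound 1 `O=c1cc(O)c2ccc(OCc3cccc(F)c3)cc2o1` gives 2090 nM in this assay. Compound 2 `CCOc1cc(=O)oc2cc(OCc3cccc(Cl)c3)ccc12` gives 115 nM. Compound 3 `CC(=O)COc1cc(=O)oc2cc(OCc3cccc(Cl)c3)ccc12` gives 26.9 nM, the lowest number of the three; the gap to compound 2 and the larger gap to compound 1 both lie beyond the scatter.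

Compound 4 `CN(C)C(=O)COc1cc(=O)oc2cc(OCc3cccc(Cl)c3)ccc12` has not yet been measured. It differs from compound 3 by dimethylamino in place of methyl on a carbonyl carbon. Within the data shown here, only one measured step touches the same side chain: a 4.3-fold lower number from compound 2 to compound 3 (0.63 log units; beyond the scatter). Among the measured compounds shown here, that step shows the side chain on the oxygen of the core matters in this assay, but it does not show how a dimethylcarbamoyl group compares with an acetyl group, since no compound carrying an amide there has been measured. On that basis the author expects compound 4 to stay in the same region as compound 3, with a step of a 1.5-fold higher number from compound 3 to compound 4 (0.17 log units; within the scatter) that may well fall within the scatter. The estimate for compound 4 in this assay is 40 nM, with a range from 10 nM to 160 nM.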

Compound 4, half-maximal inhibitory concentration: 501 nM
Beside the measured number, compound 4's estimate is 13-fold (1.10 log units) below it; measured number outside the range, above it.
By their numbers in this assay, from the lowest: compound 3; then compound 2; then compound 4; then compound 1.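

In this assay the change from acetyl to dimethylcarbamoyl gives a 19-fold higher number from compound 3 to compound 4 (1.27 log units; beyond the scatter) in this series, so the group on this carbonyl carbon strongly affects the read-out, and a carbonyl on the side chain does not by itself secure the low number. Measured against the simple chain of compound 2, the amide gives a 4.4-fold higher number from compound 2 to compound 4 (0.64 log units; beyond the scatter) on the same chain carbon, while the ketone gives a 4.3-fold lower number from compound 2 to compound 3 (0.63 log units; beyond the scatter) there, so the two carbonyl groups move the number in opposite directions. Nothing measured here explains why the amide and the ketone part ways.

The compounds shown leave open whether the rise in the number belongs to the amide nitrogen itself or to its two methyl groups, a question that a primary amide, an N-methyl amide or a methyl ester on the same carbonyl carbon would address. They also leave open how a carboxylic acid in this place, or a longer chain between the core oxygen and the carbonyl, would read in this assay.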